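Adding a Methoxy to Compound 3

A few compounds are considered here, and "the series" means these few. Any claim that something is new, unique, unknown or untested is made for them only; others in the source may bear on it.

Of the compounds shown here, three built on a shared core have been read in a functional assay on PC-3 cells (Homo sapiens) for inhibition, read by sulforhodamine B assay, with a stated time of 48 h, tested at 50 uM; a higher number here means more inhibition of growth at the concentration tested, a lower number less inhibition of growth. Compound 1 `COc1cc(/C=C/C(=O)/C=C/c2cccc3ccccc23)ccc1OCc1cn(CCCOc2cc(=O)oc3ccccc23)nn1`, which carries naphthalen-1-yl, gives 8%. The entry for compound 2 `COc1cccc(/C=C/C(=O)/C=C/c2ccc(OCc3cn(CCCOc4cc(=O)oc5ccccc45)nn3)c(OC)c2)c1` reads "not active" (no number reported), with no number attached. Compound 3 `COc1ccc(/C=C/C(=O)/C=C/c2ccc(OCc3cn(CCCOc4cc(=O)oc5ccccc45)nn3)c(OC)c2)cc1OC`, which carries 3,4-dimethoxyphenyl, gives 9%. Compound 3 therefore stands level with compound 1 within the scatter, and inhibition of growth is low for both at the concentration tested.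

The next compound is compound 4 `COc1cc(/C=C/C(=O)/C=C/c2cc(OC)c(OC)c(OC)c2)ccc1OCc1cn(CCCOc2cc(=O)oc3ccccc23)nn1`, and the change is methoxy in place of hydrogen on an aromatic carbon. In words, methoxy takes the place of hydrogen on an aromatic carbon, which turns 3,4-dimethoxyphenyl into 3,4,5-trimethoxyphenyl. Among the compounds with values here, no measured step makes this exact change. Within the data shown here, compound 2 has no number and offers no step. Among the measured compounds shown here, the only measured step that bears on it is a number 1 percentage points higher from compound 1 to compound 3 (within the scatter), which replaces a whole group at the same end of the molecule and still stays within the scatter. Against that background, a single added methoxy is not expected to move the reading much. The expected step is a number 1 percentage points higher from compound 3 to compound 4 (within the scatter), so no change beyond the scatter is anticipated. Compound 4 is estimated at 10%, with an expected range from 3% to 20%.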

Compound 4, percent growth inhibition at one concentration: 12%
For compound 4 the middle estimate is 2 percentage points below the measured one; low and high end bracket the measured number.
By their numbers in this assay, from the lowest: compounds 1, 3 and 4 (each within the scatter of the next).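

In this assay, within the data shown here, the added methoxy, which turns 3,4-dimethoxyphenyl into 3,4,5-trimethoxyphenyl, gives a number 3 percentage points higher from compound 3 to compound 4 (within the scatter), and this is the first reading of a change at this single aromatic carbon, which is ortho to a methoxy group and meta to both a large group and a second methoxy group. This carbon therefore takes a methoxy in place of hydrogen without the reading leaving the scatter, and the whole-group exchange gives a number 4 percentage points higher from compound 1 to compound 4 (within the scatter), so the naphthalen-1-yl and 3,4,5-trimethoxyphenyl ends also cannot be told apart at the concentration tested. No evidence is available that bears on this result.

The compounds shown carry only hydrogen or methoxy at this carbon, so it remains open whether an amine, a carboxylic acid or a longer alkoxy chain there would move the reading beyond the scatter. From the compounds shown here alone, compound 2 has no number to place beside the others, so it remains open how its single methoxy on that ring compares with the two and three methoxy groups of compound 3 and compound 4.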